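The source may report more compounds than this note shows. Statements on the series, on what has been measured and on what is new or still open speak of the compounds shown alone.

Measured in a functional assay on HeLa cells (Homo sapiens) for antiproliferative activity, read by MTT assay, with a stated time of 72 h; a higher number here means a weaker inhibitor, a lower number a stronger inhibitor:
- compound 1 `CCC/C=C/C(=O)Nc1cccc(Oc2nc(Nc3ccn(C)n3)nc3c2CSCC3)c1`: 17000 nM
- compound 2 `C=CC(=O)Nc1cccc(Oc2nc(Nc3cccc(C#N)c3)nc3c2CSCC3)c1`: 34900 nM
- compound 3 `C/C=C/C(=O)Nc1cccc(Oc2nc(Nc3cccc(C#N)c3)nc3c2CSCC3)c1`: 12800 nM

Compound 3 lies within the scatter of compound 1 and well under compound 2. Compound 4 `CCC/C=C/C(=O)Nc1cccc(Oc2nc(Nc3cccc(C#N)c3)nc3c2CSCC3)c1` follows from compound 3 by ethyl in place of hydrogen on a saturated chain carbon bound to a double-bonded chain carbon, which turns prop-1-en-1-yl into pent-1-en-1-yl. Within the data shown here, the one measured step on this chain is a 2.7-fold lower number from compound 2 to compound 3 (0.44 log units; beyond the scatter), a modest change. Compound 1 already carries pent-1-en-1-yl on a different amine, and its value of 17000 nM gives no sign of a large shift. In this assay, no change beyond the scatter is therefore expected, and the estimate is a 1.2-fold lower number from compound 3 to compound 4 (0.07 log units; within the scatter). For compound 4 the expected value is 11000 nM, with an estimated range of 5000 nM to 24000 nM.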

Compound 4, half-maximal inhibitory concentration: 7220 nM
Estimate against measurement, compound 4: 1.5-fold (0.18 log units) above; low and high end bracket the measured number.
By their numbers in this assay, from the lowest: compounds 4, 3 and 1 (each within the scatter of the next, the first and the last beyond it); then compound 2.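

In this assay, ethyl in place of hydrogen on the saturated chain carbon gives (a 1.8-fold lower number from compound 3 to compound 4 (0.25 log units; within the scatter)), so the extension from prop-1-en-1-yl to pent-1-en-1-yl stays small, whereas pent-1-en-1-yl in place of vinyl on the carbonyl carbon gives (a 4.8-fold lower number from compound 2 to compound 4 (0.68 log units; beyond the scatter)). Among these compounds, with pent-1-en-1-yl held fixed, 3-cyanophenyl in place of 1-methyl-1H-pyrazol-3-yl on the nitrogen gives (a 2.4-fold lower number from compound 1 to compound 4 (0.37 log units; beyond the scatter)), the first readable step at that position. No supporting data bear on the cause of these steps.

Open, as far as these compounds go, is how a longer chain or a terminal amine on the carbonyl side would read. Also open, from the compounds shown here alone, is whether the vinyl step holds with 1-methyl-1H-pyrazol-3-yl.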